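The source may hold more compounds than are shown below. What is called first, only, known or untested is meant among the compounds shown, and "the series" means these compounds.

Three compounds share one core and differ only in the aromatic group attached to a nitrogen on an aromatic ring of that core. Compound 1 `CC(C)n1cc(Nc2ncc(C3CC3)c(NCCCNC(=O)C3CCC3)n2)cn1` carries a 1-isopropyl-1H-pyrazol-4-yl group and in an assay on isolated protein for inhibition of serine/threonine-protein kinase TBK1 (Homo sapiens) (on this read-out higher numbers stand for weaker inhibition and lower numbers for stronger inhibition), compound 1 gives 4 nM. Compound 2 `O=C(NCCCNc1nc(Nc2cncnc2)ncc1C1CC1)C1CCC1` carries a pyrimidin-5-yl group and in this assay compound 2 gives 3200 nM, which is an 800-fold higher number from compound 1 to compound 2 (2.90 log units; beyond the scatter). Compound 3 `O=C(NCCCNc1nc(Nc2cccc(F)c2)ncc1C1CC1)C1CCC1` carries a 3-fluorophenyl group and in this assay compound 3 gives 8 nM. Compound 3 thus stands second highest of the three numbers; the nearer step is a 2.0-fold higher number from compound 1 to compound 3 (0.30 log units; within the scatter), and the further one is a 400-fold lower number from compound 2 to compound 3 (2.60 log units; beyond the scatter).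

Compound 4 `CN(C)Cc1ccc(Nc2ncc(C3CC3)c(NCCCNC(=O)C3CCC3)n2)cc1` is not yet measured. It differs from compound 3 in that (4-((dimethylamino)methyl)phenyl in place of 3-fluorophenyl on a nitrogen on an aromatic ring). The six-membered carbon ring stays, and only its substituent changes. The measured steps show that the six-membered carbon ring of compound 3 and the pyrazole of compound 1 give numbers within the scatter of each other, while only the pyrimidine of compound 2 stands far apart. Since compound 4 keeps the carbon ring, the expected step is a 1.3-fold higher number from compound 3 to compound 4 (0.10 log units; within the scatter), that is, no change beyond the scatter. For compound 4 in this assay the estimate is 10 nM, with a range from 3 nM to 40 nM.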

Compound 4, half-maximal inhibitory concentration: 6 nM
Compound 4: the middle estimate sits 1.7-fold (0.22 log units) above what was measured, within the range that was stated.
By their numbers in this assay, from the lowest: compounds 1, 4 and 3 (each within the scatter of the next); then compound 2.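

In this assay, the 4-((dimethylamino)methyl)phenyl group, with 10 heavy atoms and 1 hydrogen-bond acceptor, replaces the 3-fluorophenyl group, with 7 heavy atoms and no acceptor, and gives a 1.3-fold lower number from compound 3 to compound 4 (0.12 log units; within the scatter). This shows that this place, on a nitrogen on an aromatic ring, can take a bigger group carrying a nitrogen in its side chain without a change beyond the scatter, and the same holds against the pyrazole group in a 1.5-fold higher number from compound 1 to compound 4 (0.18 log units; within the scatter). Compounds 1, 3 and 4 thus form a group within the scatter of one another, with compound 2 as the one exception, as a 530-fold lower number from compound 2 to compound 4 (2.73 log units; beyond the scatter) makes plain, and nothing available explains why the pyrimidin-5-yl group stands so far apart.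

Going by these compounds, it remains open whether a carboxylic acid or a morpholine on the six-membered carbon ring would read like the dimethylamino group. A longer chain between that ring and the amine is equally untested by the compounds shown, so how much room this place allows is still unknown.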